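This account rests on a few compounds, and the source may have more. Where it says the series, first, only, none or still open, it means among the compounds named here.

Compound 1 `CCn1c(-c2cnc(C)nc2)nc2c(N[C@H]3CCN(C(=O)C4CC(F)(F)C4)C3)ncnc21` sits second highest of the three measured numbers in a physicochemical assay for lipophilicity, read by HPLC (a lower number here means a more polar compound, a higher number a more lipophilic compound), where compound 1 gives 1.5. Compound 2 `CCn1c(-c2cnc(C)nc2)nc2c(O[C@H]3CCN(C(=O)C4CCC4)C3)ncnc21` gives 1.3 in this assay, a number within the scatter of compound 1. Compound 3 `CCn1c(-c2ccc(C(F)(F)F)nc2)nc2c(O[C@H]3CCN(C(=O)[C@H]4C[C@@H](OC)C4)C3)ncnc21` gives 2.2 in this assay, clearly the higher of the two when set against compound 1. Compound 4 `CCn1c(-c2cnc(C)nc2)nc2c(N[C@H]3CCN(C(=O)[C@H]4C[C@@H](OC)C4)C3)ncnc21` is not yet measured in this assay; it differs from compound 1 in one place, (3-methoxycyclobutyl in place of 3,3-difluorocyclobutyl on a carbonyl carbon). Going by the values given here, no measured pair isolates this change, so its size is not known from the numbers. The step from compound 1 to compound 4 is expected to be small, at most at the edge of the scatter, a number 0.20 log units lower from compound 1 to compound 4 (within the scatter), with a slight lowering judged more likely than a rise. In this assay compound 4 is estimated at 1.3, with a range of 0.9 to 1.7.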

Compound 4, distribution coefficient: 0.9
Compound 4: middle estimate off by 0.40 log units, on the high side; the measured number falls inside the stated range.
By their numbers in this assay, from the lowest: compound 4; then compounds 2 and 1 (each within the scatter of the next); then compound 3.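

On a carbonyl carbon bound to an amide-type ring nitrogen, the first single-place step gives a number 0.60 log units lower from compound 1 to compound 4 (beyond the scatter) in this assay at this position. The two groups have the same heavy-atom count, and the step comes with a swap of fluorine for oxygen and one added hydrogen-bond acceptor. Nothing at hand explains its size.

One pair cannot show whether the step carries over to other compounds in the series. From the compounds shown here alone, how a hydroxyl or an amine on the cyclobutyl ring, or a longer chain in its place, would read in this assay remains open.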